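The source may hold more compounds than are shown below. What is called first, only, known or untested is meant among the compounds shown, and "the series" means these compounds.

Compound 1 `C#CCCOC(=O)c1ccc(C(CC)(CC)c2ccc(OCCC(O)(CC)CC)c(C)c2)n1CC` carries a (but-3-yn-1-yl)oxy group on its carbonyl carbon. Going by the values given here, in an assay on cells for agonist activity at vitamin D3 receptor (Homo sapiens), with a stated time of 96 h (a higher number here means that more compound is needed for the effect, a lower number that less compound is needed), compound 1 gives 6030 nM, the highest of the two numbers known so far. Compound 2 `CCC(C)C(NC(=O)c1ccc(C(CC)(CC)c2ccc(OCCC(O)(CC)CC)c(C)c2)n1CC)C(=O)O`, in which (1-carboxy-2-methylbutyl)amino stands in place of that group on the carbonyl carbon, gives 860 nM in this assay; the step between them is a 7.0-fold lower number from compound 1 to compound 2 (0.85 log units; beyond the scatter). Compound 3 `CCn1c(C(=O)NC(CO)CCO)ccc1C(CC)(CC)c1ccc(OCCC(O)(CC)CC)c(C)c1` differs from compound 1 on the same carbonyl carbon: a group of 7 heavy atoms (4 carbon, 1 nitrogen, 2 oxygen; no ring) in place of a group of 5 heavy atoms (4 carbon, 1 oxygen; no ring), on a carbonyl carbon. Among the compounds with values here, the only measured step that bears on this change, a 7.0-fold lower number from compound 1 to compound 2 (0.85 log units; beyond the scatter), likewise removed the (but-3-yn-1-yl)oxy group from the carbonyl carbon and brought a modest improvement. A step in the same direction, though not necessarily of the same size, is therefore expected for compound 3, a 4.0-fold lower number from compound 1 to compound 3 (0.60 log units; beyond the scatter). Compound 3 is estimated at 1500 nM, within a range of 500 nM to 5000 nM.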

Compound 3, half-maximal effective concentration: 2490 nM
Compound 3: middle estimate off by 1.7-fold (0.22 log units), on the low side; low and high end bracket the measured number.
By their numbers in this assay, from the lowest: compound 2; then compound 3; then compound 1.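

Compound 3 shows that the lower number on this carbonyl carbon is not confined to the 1-carboxy-2-methylbutyl group of compound 2: in this assay, a second group attached through an amide-type nitrogen also replaces the (but-3-yn-1-yl)oxy group with a gain, a 2.4-fold lower number from compound 1 to compound 3 (0.38 log units; beyond the scatter). The group on that nitrogen matters as well, since 3-hydroxy-1-(hydroxymethyl)propyl in place of 1-carboxy-2-methylbutyl gives a 2.9-fold higher number from compound 2 to compound 3 (0.46 log units; beyond the scatter), which leaves compound 2 with the lowest number of the three. Nothing available here gives a reason for either step.

The compounds shown leave open whether the carboxylic acid or the branched carbon chain of compound 2 accounts for its lower number. A plain ethylamino group, or a carboxymethylamino group with a shorter chain, on the same carbonyl carbon would begin to separate these two parts.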